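Halogenated aryl enones on a shared core: bromine moved

This account rests on a few compounds, and the source may have more. Where it says the series, first, only, none or still open, it means among the compounds named here.

Measured in a functional assay on the whole organism for inhibition, with Mus musculus as the target, with a stated time of 1 h, at a dose of 30 mg/kg by the intraperitoneal route; on this read-out higher numbers stand for more inhibition at the one dose given (going by the name of the read-out) and lower numbers for less inhibition:
compound 1 `O=C(/C=C/C1=Cc2ccccc2OC1)c1ccccc1F`: 64.4%
compound 2 `O=C(/C=C/C1=Cc2ccccc2OC1)c1ccccc1Cl`: 52.3%
compound 3 `O=C(/C=C/C1=Cc2ccccc2OC1)c1cccc(Br)c1`: 51.7%

Compound 3 holds the smallest of the three numbers, but the gap to compound 2 lies within the scatter, a number 0.6 percentage points lower from compound 2 to compound 3 (within the scatter); the gap to compound 1 is the larger one, a number 12.7 percentage points lower from compound 1 to compound 3 (beyond the scatter), beyond it.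

Compound 4 `O=C(/C=C/C1=Cc2ccccc2OC1)c1ccc(Br)cc1` is unmeasured. It differs from compound 3 by 4-bromophenyl in place of 3-bromophenyl on a carbonyl carbon. Among the compounds with values here, no measured step moves a halogen on its own: a number 12.7 percentage points lower from compound 1 to compound 3 (beyond the scatter) and a number 0.6 percentage points lower from compound 2 to compound 3 (within the scatter) each change halogen and place together, running from modest to nil, while a number 12.1 percentage points lower from compound 1 to compound 2 (beyond the scatter) changes only the halogen. Nothing here isolates position alone, so in this assay no step beyond the scatter is expected, a number 1.7 percentage points lower from compound 3 to compound 4 (within the scatter). Compound 4 is estimated at 50%, expected between 36% and 64%.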

Compound 4, a percentage reported as inhibition, in the whole organism at one dose (the size of the read-out at that dose, not a potency): 66%
Estimate against measurement, compound 4: 16 percentage points below, outside the stated range (above it).
By their numbers in this assay, from the lowest: compounds 3 and 2 (each within the scatter of the next); then compounds 1 and 4 (each within the scatter of the next).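

Moving bromine alone is the first change in the series that isolates position, and it is not silent in this assay: a number 14.3 percentage points higher from compound 3 to compound 4 (beyond the scatter), with 4-bromophenyl in place of 3-bromophenyl on a carbonyl carbon. Compound 4 also separates from the chloro compound, a number 13.7 percentage points higher from compound 2 to compound 4 (beyond the scatter), while a number 1.6 percentage points higher from compound 1 to compound 4 (within the scatter) leaves it level with the fluoro compound, though both these steps change halogen and place together. Nothing available explains the effect of moving bromine. As far as these compounds go, whether chloro or fluoro responds to the same move remains open. So does whether an amine or a carboxylic acid in place of bromine would hold the read-out.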